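The source may report more compounds than this note shows. Statements on the series, on what has been measured and on what is new or still open speak of the compounds shown alone.

Measured in an ADME assay on RAW264.7 cells (Mus musculus) for cytotoxicity, read by MTT assay, with a stated time of 48 h; a lower number here means a stronger inhibitor, a higher number a weaker inhibitor:
compound 1 `CCS(=O)(=O)Nc1ccc(NC(=O)c2ccc(Cl)c([N+](=O)[O-])c2)cc1C` gives 141000 nM
compound 2 `Cc1cc(NC(=O)c2ccc(Cl)c([N+](=O)[O-])c2)ccc1NS(=O)(=O)C(F)(F)F` gives 89800 nM
compound 3 `CCS(=O)(=O)Nc1ccc(NC(=O)c2ccc(Cl)cc2)cc1OC` gives 60100 nM

Compound 1 and compound 2 share one core and differ in a single place: trifluoromethyl in place of ethyl on a sulfonyl sulfur. In this assay this change gave a 1.6-fold lower number from compound 1 to compound 2 (0.20 log units; within the scatter). Compound 3 stands on a second core; the difference between the core of compound 3 and the core of compound 1 is not broken down here. The number for compound 3 sits within the scatter of the number for compound 2, and only against compound 1 does the gap lie beyond it.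

Compound 4 `COc1cc(NC(=O)c2ccc(Cl)cc2)ccc1NS(=O)(=O)C(F)(F)F` is not yet measured. It differs from compound 3 by trifluoromethyl in place of ethyl on a sulfonyl sulfur. The place reads word for word as in the change from compound 1 to compound 2, so this is the same change, now made on the other core. Set beside the earlier step, the step from compound 3 to compound 4 is expected to be a 1.6-fold lower number from compound 3 to compound 4 (0.20 log units; within the scatter). This rests on a single precedent, a 1.6-fold lower number from compound 1 to compound 2 (0.20 log units; within the scatter), which stayed within the scatter; with only one case, a larger or smaller step cannot be ruled out. Compound 4 is estimated to give about 38000 nM, most likely between 18000 nM and 80000 nM.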

Compound 4, half-maximal inhibitory concentration: 108000 nM
Compound 4: middle estimate off by 2.8-fold (0.45 log units), on the low side; measured number outside the range, above it.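

In this assay, trifluoromethyl in place of ethyl on the sulfonyl sulfur gives a 1.8-fold higher number from compound 3 to compound 4 (0.25 log units; within the scatter). Set beside the earlier case, the two steps point opposite ways, and this change does not carry over from one core to the other as one fixed shift: the same change on two cores in this assay, a 1.6-fold lower number (0.20 log units; within the scatter) from compound 1 to compound 2 and a 1.8-fold higher number (0.25 log units; within the scatter) from compound 3 to compound 4, 2.8-fold (0.45 log units) apart, beyond the scatter of two such steps. Each step alone stays within the scatter, and neither is shown to be a real effect on its own core; with a single pair per core, the gap between the steps cannot be tied to any particular difference between the cores.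

Open, on these data alone, is whether other groups on the sulfonyl sulfur, such as a longer chain like propyl or butyl, or a dimethylamino group, would follow either step on these two cores. Also open, as far as these compounds go, is whether trifluoromethyl in place of ethyl on a third core would fall nearer one step or the other.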